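Moving fluorine and nitrogen within a pyridine ring

The source may report more compounds than this note shows. Statements on the series, on what has been measured and on what is new or still open speak of the compounds shown alone.

Three measured compounds share one core and differ only in the aromatic group at its far end. Compound 1 `COc1ccc(-c2ccc(COCCCCCN3C[C@H](O)[C@@H](O)[C@H](O)[C@H]3CO)cc2)cc1` gives 25 nM in an assay on isolated protein for inhibition of ceramide glucosyltransferase (Homo sapiens); a higher number here means a weaker inhibitor, a lower number a stronger inhibitor. Compound 2 `COc1ccccc1-c1ccc(COCCCCCN2C[C@H](O)[C@@H](O)[C@H](O)[C@H]2CO)cc1` gives 50 nM in this assay, and compound 3 `OC[C@@H]1[C@@H](O)[C@H](O)[C@@H](O)CN1CCCCCOCc1ccc(-c2ccnc(F)c2)cc1` gives 150 nM in this assay. Compound 3 therefore stands at the weak end of these three: the step of a 6.0-fold higher number from compound 1 to compound 3 (0.78 log units; beyond the scatter) and the step of a 3.0-fold higher number from compound 2 to compound 3 (0.48 log units; beyond the scatter) both lie beyond the scatter, whereas the step of a 2.0-fold higher number from compound 1 to compound 2 (0.30 log units; within the scatter) stays within it.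

Compound 4 `OC[C@@H]1[C@@H](O)[C@H](O)[C@@H](O)CN1CCCCCOCc1ccc(-c2ccc(F)nc2)cc1` carries the same atoms as compound 3, joined differently: 6-fluoropyridin-3-yl in place of 2-fluoropyridin-4-yl on an aromatic carbon. Going by the values given here, no measured step rearranges a pyridine in this way, so the closest guide is the step from compound 1 to compound 2, where one methoxyphenyl isomer replaced another without a step beyond the scatter. The estimated step of no change at the digits printed from compound 3 to compound 4 (within the scatter) in this assay is accordingly expected to be small. Compound 4 is expected to give 150 nM in this assay, with a range of 60 nM to 400 nM.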

Compound 4, half-maximal inhibitory concentration: 750 nM
For compound 4 the middle estimate is 5.0-fold (0.70 log units) below the measured one, and the stated range ends below it.
By their numbers in this assay, from the lowest: compounds 1 and 2 (each within the scatter of the next); then compound 3; then compound 4.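

Swapping 2-fluoropyridin-4-yl for 6-fluoropyridin-3-yl is not a neutral change at this position: it gives (a 5.0-fold higher number from compound 3 to compound 4 (0.70 log units; beyond the scatter)), although the two groups have the same atoms and the same counted hydrogen-bond donors and acceptors. The earlier methoxyphenyl isomers differed by no more than the scatter, so that pair does not predict how an isomer swap behaves among the fluoropyridines. The methoxyphenyl compounds also stand well apart from the new compound, with (a 15-fold higher number from compound 2 to compound 4 (1.18 log units; beyond the scatter)) and (a 30-fold higher number from compound 1 to compound 4 (1.48 log units; beyond the scatter)), which makes compound 4 the weakest inhibitor of the four in this assay.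

No measurement shown here accounts for the gap between the two fluoropyridines. Also open, on these data alone, is how either pyridine arrangement would fare with an amine or a nitrile in place of the fluorine.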